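The source may report more compounds than this note shows. Statements on the series, on what has been measured and on what is new or still open speak of the compounds shown alone.

Measured so far:
compound 1, `CCCn1nc(C(=O)N[C@H]2COc3ccccc3N(C)C2=S)nc1Cc1ccccc1`: 288 nM
compound 2, `CCCCCn1nc(C(=O)N[C@H]2COc3ccccc3N(C)C2=S)nc1Cc1ccccc1`: 805 nM

Within the data shown here, compound 2 holds the highest of the two numbers in a functional assay on HT-29 cells (Homo sapiens) for inhibition, read by luminescence and CellTiter-Glo, with a stated time of 24 h; on this read-out lower numbers stand for an effect already at smaller amounts and higher numbers for an effect only at larger amounts of compound; its nearest neighbour is compound 1, and the only measured step runs a 2.8-fold higher number from compound 1 to compound 2 (0.45 log units; beyond the scatter). Compound 3, `CN1C(=S)[C@@H](NC(=O)c2nc(Cc3ccccc3)n(CCC(F)(F)F)n2)COc2ccccc21`, has not been measured. Its change from compound 2 is trifluoromethyl in place of propyl on a saturated chain carbon, two bonds along the chain from an aromatic nitrogen. Among the measured compounds shown here, the single measured step bears on this only loosely: it shows that lengthening the chain raised the number, and the change to compound 3 shortens the chain again while bringing in fluorine. Because a 2.8-fold higher number from compound 1 to compound 2 (0.45 log units; beyond the scatter) went upward, a step back downward is expected for compound 3, although the trifluoromethyl group has no precedent among these compounds and the expectation is held loosely. Compound 3 is therefore expected to give 450 nM in this assay, within 150 nM to 1400 nM, an estimated step of a 1.8-fold lower number from compound 2 to compound 3 (0.25 log units; within the scatter).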

Compound 3, half-maximal effective concentration: 1550 nM
Beside the measured number, compound 3's estimate is 3.4-fold (0.54 log units) below it; the measured number lies above the stated range.
By their numbers in this assay, from the lowest: compound 1; then compounds 2 and 3 (each within the scatter of the next).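

In this assay the change of trifluoromethyl in place of methyl gives a 5.4-fold higher number from compound 1 to compound 3 (0.73 log units; beyond the scatter) and so moves the number at this position beyond the scatter, just as the pentyl chain of compound 2 does. The position therefore responds to a change at the end of the chain as well as to the longer chain, while a 1.9-fold higher number from compound 2 to compound 3 (0.28 log units; within the scatter) leaves compound 2 and compound 3 not separated from each other. No measurement here accounts for this result.

Going by these compounds, what an amine, a hydroxyl or a carboxylic acid at the end of this chain would give stays open, as does the effect of a branched chain or of a 2,2,2-trifluoroethyl group. The compounds shown also leave open whether these steps would hold on any other cells or read-out.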